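Cytotoxicity Limits and a Single Stereocentre Inversion

A few compounds are considered here, and "the series" means these few. Any claim that something is new, unique, unknown or untested is made for them only; others in the source may bear on it.

Of the compounds shown here, three have been measured in an ADME assay on cells (kidney, Oryctolagus cuniculus) for cytotoxicity; on this read-out higher numbers stand for lower toxicity in this test and lower numbers for higher toxicity in this test. Compound 1 `CC(=O)Nc1ccn(C2OC(CO[Si](C)(C)C(C)(C)C)C(C#N)C2O[Si](C)(C)C(C)(C)C)c(=O)n1` gives > 4 ug/mL, which is a limit of the assay rather than a number. Compound 3 `CC(C)(C)[Si](C)(C)OCC1OC(n2ccc(N)nc2=O)C(O[Si](C)(C)C(C)(C)C)C1C#N` gives > 10 ug/mL, again only a limit. The step that the two limits leave unreadable from compound 1 to compound 3 cannot be sized, because the limit of > 4 ug/mL in this assay, at which 1 of the 3 values shown sits, and the limit of > 10 ug/mL in this assay, at which 1 of the 3 values shown sits, bound both of its ends.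

Compound 2 `CC(C)(C)[Si](C)(C)OC[C@H]1O[C@@H](n2cnc3c(N)ncnc32)[C@H](O[Si](C)(C)C(C)(C)C)[C@H]1C#N` gives in this assay the value > 100 ug/mL, once more a limit and not a number. For the measured compounds named here, compound 2 thus stands at the limit of > 100 ug/mL in this assay, at which 1 of the 3 values shown sits, and the two further values shown are also limits, so no measured step touches it.

Compound 4 `CC(C)(C)[Si](C)(C)OC[C@H]1O[C@@H](n2cnc3c(N)ncnc32)[C@H](O[Si](C)(C)C(C)(C)C)[C@@H]1C#N` differs from compound 2 by the two compounds have the same atoms and bonds and differ only in configuration as drawn: 1 of 4 stereo elements differ; a stereocentre at a saturated ring carbon is drawn S in compound 2 and R in compound 4. Going by the values given here, no measured pair differs in this way, and the only measured step is unreadable, so the data give no ground to expect a shift in this assay beyond the usual scatter. Compound 4 is therefore expected to give about 100 ug/mL, with an expected range from 30 ug/mL to 300 ug/mL. The step of a number no higher from compound 2 to compound 4 (the limit leaves the size open) that this estimate means is expected to be none beyond the scatter, and a limit rather than a number is the likelier outcome.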

Compound 4, minimum cytotoxic concentration: 10 ug/mL
Compound 4: the middle estimate sits 10-fold (1.00 log units) above what was measured; measured number below the stated range.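

In this assay, for the compounds shown here, the change at this stereocentre, a saturated ring carbon drawn S in compound 2 and R in compound 4, gives an at least 10-fold lower number from compound 2 to compound 4 (1.00 log units; beyond the scatter) and is the only step in the set whose size can at least be bounded, since the earlier step between the other two compounds cannot be read. Going by these compounds alone, compound 2 keeps its value of > 100 ug/mL as a limit, so the true size of the step may be larger than the printed bound, but compound 4 is the first compound here to give a number rather than a limit. The shift in this assay can be assigned to configuration alone, with no group entering or leaving, because of this: the fact that compounds 2 and 4 differ only in the configuration as drawn.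

The compounds shown leave open whether the same inversion would move the read-out on the core of compound 3, where the base differs and the configuration is not drawn. They also leave open whether the effect belongs to the nitrile itself at this stereocentre, or would persist with an amine or a carboxylic acid in its place.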